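A few compounds are considered here, and "the series" means these few. Any claim that something is new, unique, unknown or untested is made for them only; others in the source may bear on it.

Measured compounds:
compound 1, `CCCSc1nnc(COc2cc(C)c3c(C)cc(=O)oc3c2)o1` — > 100000 nM
compound 2, `CCCCSc1nnc(COc2cc(C)c3c(C)cc(=O)oc3c2)o1` — > 100000 nM
compound 3, `CCCCCSc1nnc(COc2cc(C)c3c(C)cc(=O)oc3c2)o1` — > 100000 nM

In a functional assay on MDA-MB-231 cells (Homo sapiens) for antiproliferative activity, read by MTT assay, with a stated time of 24 h (a lower number here means a stronger inhibitor, a higher number a weaker inhibitor), compound 1 reports a limit, > 100000 nM, not a number. Compound 2 likewise sits at a limit in this assay, > 100000 nM. Compound 3 also gives only a limit, > 100000 nM. All three share one core and differ only in the alkyl chain on the sulfur. The steps between them, a step that the two limits leave unreadable from compound 1 to compound 2, a step that the two limits leave unreadable from compound 1 to compound 3 and a step that the two limits leave unreadable from compound 2 to compound 3, are unreadable in size because of the limit of > 100000 nM in this assay, at which 3 of the 3 values shown sit.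

Compound 4, `Cc1cc(OCc2nnc(SCc3cccc(F)c3)o2)cc2oc(=O)cc(C)c12`, is not yet measured. Relative to compound 3 the change is 3-fluorophenyl in place of butyl on a saturated chain carbon bound to a sulfur. Among the measured compounds shown here, no measured step bears on an aromatic group at this position; the chain-lengthening steps from compound 1 to compound 3 show only that every alkyl chain tested stays at the limit. The step of an at least 1.2-fold lower number from compound 3 to compound 4 (0.09 log units; that floor lies within the scatter) is therefore expected to be small or absent, with a real chance that compound 4 also returns only a limit. Compound 4 is estimated at 80000 nM, range 15000 nM to 400000 nM.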

Compound 4, half-maximal inhibitory concentration: > 100000 nM
Compound 4 ended at the assay's limit; the forecaster's own chance of this, stated with the estimate: 55%; at least 1.2-fold (0.09 log units) between middle value and limit.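

No step from compound 4 to compound 1, compound 2 or compound 3 can be read in size: the limit of > 100000 nM in this assay, at which 4 of the 4 values shown sit.

The compounds shown leave open what number any of the four would give in this assay, and whether any group on the sulfur of the shared core gives a measurable value.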